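Solubility step from compound 2 to compound 3

The source may hold more compounds than are shown below. What is called first, only, known or untested is meant among the compounds shown, and "the series" means these compounds.

Among the compounds with values here, in a physicochemical assay for solubility, read by LC-MS, using the shake flask method, measured as thermodynamic solubility, with a stated time of 24 h, at pH 6.5 (a lower number here means a less soluble compound, a higher number a more soluble compound), compound 2 (`O=[N+]([O-])c1ccc(-n2cc(CO[C@H]3O[C@H](CO)[C@@H](O)[C@H](O)[C@@H]3O)nn2)cc1`) gives 2600 ug/mL, the only actual number so far. Compound 1 (`COc1ccc(Cn2cc(CO[C@H]3O[C@H](CO)[C@@H](O)[C@H](O)[C@@H]3O)nn2)cc1`) gives > 3000 ug/mL, which is a limit. Compound 3 (`OC[C@H]1O[C@H](OCc2cn(-c3cccc(F)c3)nn2)[C@@H](O)[C@@H](O)[C@@H]1O`) carries 3-fluorophenyl in place of 4-nitrophenyl on an aromatic nitrogen. Within the data shown here, the only measured step, an at least 1.1-fold lower number from compound 1 to compound 2 (0.06 log units; that floor lies within the scatter), also changes the group on an aromatic nitrogen, so no step beyond the scatter is expected in this assay. The expected step is a 1.1-fold lower number from compound 2 to compound 3 (0.03 log units; within the scatter). For compound 3 the estimate is 2400 ug/mL, with an expected range of 1100 ug/mL to 3000 ug/mL.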

Compound 3, solubility: > 3000 ug/mL
Compound 3 ended at the assay's limit; the forecaster's own chance of this, stated with the estimate: 30%; middle value at least 1.2-fold (0.09 log units) from the limit.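

In this assay compound 3 gives > 3000 ug/mL, which is a limit. Replacing 4-nitrophenyl with 3-fluorophenyl on the aromatic nitrogen removes the hydrogen-bond acceptors of the group at this position and gives an at least 1.1-fold higher number from compound 2 to compound 3 (0.06 log units; that floor lies within the scatter). The step from compound 1 to compound 3 cannot be read, and changes at this position can be sized only in part in this assay: the limit of > 3000 ug/mL in this assay, at which 2 of the 3 values shown sit.

From the compounds shown here alone, how far compound 1 and compound 3 lie past the limit remains open. Also open, going by these compounds, is whether an amine, a carboxylic acid or a longer chain on this nitrogen would give a readable step beyond the scatter.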